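Trimming a Fluoro Group: What to Expect for Compound 4

This account rests on a few compounds, and the source may have more. Where it says the series, first, only, none or still open, it means among the compounds named here.

Three measured compounds share one core and differ only in where fluoro groups sit on the outer ring. In an assay on FRT cells for positive allosteric modulation of Cystic fibrosis transmembrane conductance regulator variant N1303K (Homo sapiens), in the presence of a further agent that is not named here (on this read-out higher numbers stand for an effect only at larger amounts of compound and lower numbers for an effect already at smaller amounts), compound 1 `COc1ccc2[nH]c3c(c2c1)CCNC31CCN(Cc2cc(F)cc(F)c2)CC1` gives 11100 nM, compound 2 `COc1ccc2[nH]c3c(c2c1)CCNC31CCN(Cc2cc(F)c(F)c(F)c2)CC1` gives 2600 nM, and compound 3 `COc1ccc2[nH]c3c(c2c1)CCNC31CCN(Cc2ccc(F)c(F)c2F)CC1` gives 4100 nM. Compound 3 differs from compound 2 by 2,3,4-trifluorophenyl in place of 3,4,5-trifluorophenyl on a saturated chain carbon bound to an amine nitrogen in a ring, a step of a 1.6-fold higher number from compound 2 to compound 3 (0.20 log units; within the scatter). Compound 1 differs from compound 2 by hydrogen in place of fluoro on an aromatic carbon, which made a step of a 4.3-fold higher number from compound 2 to compound 1 (0.63 log units; beyond the scatter). Compound 4 `COc1ccc2[nH]c3c(c2c1)CCNC31CCN(Cc2cccc(F)c2F)CC1`, not yet measured, differs from compound 3 by the same kind of change: hydrogen in place of fluoro on an aromatic carbon. The surroundings are not identical: in compound 2 the carbon is ortho to two fluoro groups, whereas in compound 3 it is ortho to a fluoro group and meta to a fluoro group. Resting on compound 1 and compound 2 with a 4.3-fold higher number from compound 2 to compound 1 (0.63 log units; beyond the scatter), the step of a 2.7-fold higher number from compound 3 to compound 4 (0.43 log units; beyond the scatter) is expected, somewhat smaller. Compound 4 is estimated at 11000 nM in this assay, between 4000 nM and 35000 nM.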

Compound 4, half-maximal effective concentration: 13600 nM
The estimate for compound 4 lay 1.2-fold (0.09 log units) below the measured number; measured number inside the range.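

Removing the fluoro group from compound 3 gives a 3.3-fold higher number from compound 3 to compound 4 (0.52 log units; beyond the scatter), and this step agrees with the earlier one: the same change on two cores in this assay, a 4.3-fold higher number (0.63 log units; beyond the scatter) from compound 2 to compound 1 and a 3.3-fold higher number (0.52 log units; beyond the scatter) from compound 3 to compound 4, 1.3-fold (0.11 log units) apart, within the scatter of two such steps. Compound 4 also sits well apart from the trifluoro compound 2 (a 5.2-fold higher number from compound 2 to compound 4 (0.72 log units; beyond the scatter)) but level with the other difluoro compound (a 1.2-fold higher number from compound 1 to compound 4 (0.09 log units; within the scatter)). This shows that replacing fluoro with hydrogen carried over between these two pairs, but two pairs with closely related fluoro patterns do not establish a general rule, or show why the step occurs.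

The compounds shown leave open how other groups would compare at that place on the ring. A chloro, methyl or methoxy group, for example, might give a different number from either fluoro or hydrogen.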